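Phenyl to benzyl on the amide nitrogen of compound 2

The source may hold more compounds than are shown below. What is called first, only, known or untested is meant among the compounds shown, and "the series" means these compounds.

Of the compounds shown here, three have been measured in an assay on isolated protein for binding affinity to vascular endothelial growth factor A, long form (Homo sapiens), read by surface plasmon resonance; on this read-out higher numbers stand for weaker binding and lower numbers for tighter binding. Compound 1 `CCN(CC(=O)NC[C@H]1O[C@H](OC)[C@@H](OS(=O)(=O)O)[C@@H](OS(=O)(=O)O)[C@@H]1OS(=O)(=O)O)C(=O)CCCCCCCCCOS(=O)(=O)O` gives 545000 nM, compound 2 `CO[C@H]1O[C@H](CNC(=O)CN(C(C)=O)c2ccccc2)[C@@H](OS(=O)(=O)O)[C@H](OS(=O)(=O)O)[C@@H]1OS(=O)(=O)O` gives 76000 nM, and compound 3 `CCN(CC(=O)NCCO[C@H]1O[C@H](COS(=O)(=O)O)[C@@H](OS(=O)(=O)O)[C@H](OS(=O)(=O)O)[C@@H]1OS(=O)(=O)O)C(=O)CCCCCCCCCOS(=O)(=O)O` gives 50000 nM. Compound 2 stands second highest of the three: its number lies within the scatter of that of compound 3, while compound 1 sits beyond the scatter on the weaker side.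

Compound 4 `CO[C@H]1O[C@H](CNC(=O)CN(Cc2ccccc2)C(C)=O)[C@@H](OS(=O)(=O)O)[C@H](OS(=O)(=O)O)[C@@H]1OS(=O)(=O)O` differs from compound 2 in one place: benzyl in place of phenyl on an amide-type nitrogen. Among the measured compounds shown here, no measured pair carries this difference, so its size is unknown here. The expected step is a 1.1-fold lower number from compound 2 to compound 4 (0.04 log units; within the scatter), nothing beyond the scatter in either direction. Compound 4 is therefore expected to give about 70000 nM in this assay, with a range from 25000 nM to 200000 nM.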

Compound 4, dissociation constant: 77000 nM
The estimate for compound 4 lay 1.1-fold (0.04 log units) below the measured number, and the stated range covers the measured number.
By their numbers in this assay, from the lowest: compounds 3, 2 and 4 (each within the scatter of the next); then compound 1.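

In this assay, among the compounds shown here, benzyl in place of phenyl on the amide-type nitrogen gives a 1.0-fold higher number from compound 2 to compound 4 (0.01 log units; within the scatter), the first reading of any change at this position. Compound 2 and compound 4 therefore cannot be told apart, so at this nitrogen the assay does not distinguish the aromatic ring attached directly from one attached through a saturated carbon. No measurement here bears on why the two match. Still open, on these data alone, is whether a longer chain to the ring, or an amine or carboxylic acid on it, would separate from these two compounds.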